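Replacing a Benzyl Group with a Thiourea on the Ring Amine

A few compounds are considered here, and "the series" means these few. Any claim that something is new, unique, unknown or untested is made for them only; others in the source may bear on it.

Compound 1 `NC(=O)c1c(NC(=O)c2ccccc2Cl)sc2c1CCN(Cc1ccccc1Cl)C2`: 4430 nM
Compound 2 `NC(=O)c1c(NC(=O)c2ccc(C(F)(F)F)cc2)sc2c1CCN(Cc1ccc(Cl)cc1Cl)C2`: 10900 nM
Compound 3 `NC(=O)c1c(NC(=O)c2cccc([N+](=O)[O-])c2)sc2c1CCN(Cc1c(Cl)cccc1Cl)C2`: 13500 nM

Of the compounds shown here, three sharing one core have been tested in a functional assay on MKN-74 cells (Homo sapiens) for antiproliferative activity, with a stated time of 24 h; on this read-out higher numbers stand for weaker inhibition and lower numbers for stronger inhibition. Compound 1 gives 4430 nM, the lowest of the three values; compound 2 gives 10900 nM and compound 3 gives 13500 nM, both beyond the scatter from compound 1. The three differ in more than one place, so no single change can be read from them.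

Compound 4 `CSc1ccccc1NC(=S)N1CCc2c(sc(NC(=O)c3ccccc3Cl)c2C(N)=O)C1` is unmeasured. It differs from compound 1 on an amine nitrogen in a ring: a group of 11 heavy atoms (8 carbon, 1 nitrogen, 2 sulfur; one six-membered aromatic ring of carbon only) in place of a group of 8 heavy atoms (7 carbon, 1 chlorine; one six-membered aromatic ring of carbon only), on an amine nitrogen in a ring. For the measured compounds named here, the leaving 2-chlorobenzyl belongs to the compound with the lowest value seen here, and no measured pair shows the effect of this kind of exchange. The expected step in this assay is a 1.6-fold higher number from compound 1 to compound 4 (0.20 log units; within the scatter), a modest weakening, not far beyond the scatter. The estimate for compound 4 is 7000 nM, within 1500 nM to 30000 nM.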

Compound 4, half-maximal inhibitory concentration: 13800 nM
Compound 4: middle estimate off by 2.0-fold (0.29 log units), on the low side; measured number inside the range.
By their numbers in this assay, from the lowest: compound 1; then compounds 2, 3 and 4 (each within the scatter of the next).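

For the compounds shown here, exchanging the 2-chlorobenzyl for the thiourea group on the amine nitrogen in the ring gives the first reading of a single change: in this assay, it brings a 3.1-fold higher number from compound 1 to compound 4 (0.49 log units; beyond the scatter). The position is therefore not indifferent to what it carries, although the exchange does not remove the activity, as compound 4 still gives 13800 nM. Nothing available explains the size or direction of this step.

As far as these compounds go, this single exchange cannot separate the thiourea link from the aromatic ring it carries, so it remains open whether a urea, an amide or a plain methyl on the same nitrogen would give a lower or higher number. From the compounds shown here alone, it is also open whether the step would hold with the other benzamide groups, such as the trifluoromethyl-bearing one in compound 2.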